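The compounds below may be only part of what the source reports. "The series", "measured", "known", "first", "only" and "open" are said of these compounds alone.

Compound 1 `COc1cc(-c2nnc(SCC(=O)c3ccccc3)n2N)cc(OC)c1OC`: > 100000 nM in a functional assay on HeLa cells (Homo sapiens) for antiproliferative activity, read by MTT assay, with a stated time of 48 h (on this read-out higher numbers stand for weaker inhibition and lower numbers for stronger inhibition), a limit of the assay.
Compound 2 `COc1cccc(NC(=O)CSc2nnc(-c3cc(OC)c(OC)c(OC)c3)n2N)c1`: 4020 nM in this assay.

Within the data shown here, compound 2 holds the only numbered value in this assay; compound 1 sits at the limit (the limit of > 100000 nM in this assay, at which 1 of the 2 values shown sits). Among the measured compounds shown here, the one measured step, an at least 24-fold lower number from compound 1 to compound 2 (1.39 log units; beyond the scatter), changed the group on the carbonyl carbon. Compound 3 `COc1ccc(CNC(=O)CSc2nnc(-c3cc(OC)c(OC)c(OC)c3)n2N)cc1OC` differs from compound 2 by 3,4-dimethoxybenzyl in place of 3-methoxyphenyl on an amide-type nitrogen. For the measured compounds named here, no measured step touches this amide nitrogen, so the step from compound 1 to compound 2 bears on it only loosely. Compound 3 is therefore expected to lie near compound 2, with a modest step of a 2.0-fold higher number from compound 2 to compound 3 (0.30 log units; within the scatter), the estimate for compound 3 in this assay being 8000 nM, in the range 1500 nM to 40000 nM.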

Compound 3, half-maximal inhibitory concentration: > 100000 nM
Compound 3: no number, only a limit (the forecaster's own chance of this, stated with the estimate: 15%); at least 12-fold (1.09 log units) between middle value and limit.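

Among these compounds, on the amide nitrogen, which no earlier step had touched, the group matters in this assay: 3,4-dimethoxybenzyl in place of 3-methoxyphenyl gives an at least 24-fold higher number from compound 2 to compound 3 (1.39 log units; beyond the scatter). The amide alone is therefore not enough for a measurable value, since compound 3 keeps it and compound 2 alone holds a number. Compound 3 stands at a limit of the assay, not at a number: the limit of > 100000 nM in this assay, at which 2 of the 3 values shown sit.

This single change adds both a methylene link and a further methoxy group, and the compounds shown do not separate the two. They also leave open how an unsubstituted benzyl or a cyclohexyl group on this nitrogen would read.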